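The compounds below may be only part of what the source reports. "The series", "measured", "known", "first", "only" and "open" are said of these compounds alone.

Measured so far:
compound 1, `O=S(=O)(/C=C/c1ccc(F)cc1)Cc1ccc(Nc2ncnc3ccccc23)cc1`: in a functional assay on PC-3 cells (Homo sapiens) (on this read-out higher numbers stand for weaker inhibition of growth and lower numbers for stronger inhibition of growth), compound 1 gives 1000 nM
compound 2, `O=S(=O)(/C=C/c1ccc(Cl)cc1)Cc1ccc(Nc2ncnc3ccccc23)cc1`: compound 2 gives 43000 nM
compound 3, `O=S(=O)(/C=C/c1ccc(F)cc1Cl)Cc1ccc(Nc2ncnc3cc(Cl)ccc23)cc1`: compound 3 gives 73000 nM

Compound 2 and compound 1 differ by fluoro in place of chloro on an aromatic carbon, and the step is a 43-fold lower number from compound 2 to compound 1 (1.63 log units; beyond the scatter). Compound 3 carries a different core than compound 2; that difference is not broken down here. The values of compound 3 and compound 2 lie within the scatter of each other, while compound 1 stands far lower.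

Compound 4, `O=S(=O)(/C=C/c1ccc(F)cc1F)Cc1ccc(Nc2ncnc3cc(Cl)ccc23)cc1`, differs from compound 3 by fluoro in place of chloro on an aromatic carbon. This is the same kind of change as from compound 2 to compound 1, not the same: there the new fluoro sits para to a large group, here ortho to a large group and meta to a fluoro group. Resting on a 43-fold lower number from compound 2 to compound 1 (1.63 log units; beyond the scatter) and on the differing place, the step from compound 3 to compound 4 is expected at an 8.1-fold lower number from compound 3 to compound 4 (0.91 log units; beyond the scatter), smaller than the earlier one. Compound 4 is thus estimated at 9000 nM in this assay, expected between 2000 nM and 40000 nM.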

Compound 4, concentration for 50% growth inhibition: > 100000 nM
Compound 4: no number, only a limit; the forecaster's own chance of this, stated with the estimate: 15%; at least 11-fold (1.04 log units) between middle value and limit.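

In this assay compound 4 gives > 100000 nM, which is a limit of the assay and not a number. Fluoro in place of chloro on this core gives an at least 1.3-fold higher number from compound 3 to compound 4 (0.13 log units; that floor lies within the scatter), so the large step seen on the core of compound 1 does not carry over to the core of compound 3: the same change on two cores in this assay, a 43-fold lower number (1.63 log units; beyond the scatter) from compound 2 to compound 1 and an at least 1.3-fold higher number (0.13 log units; that floor lies within the scatter) from compound 3 to compound 4, at least 58-fold (1.77 log units) apart, beyond the scatter of two such steps

The two pairs also differ in the place of the change, here ortho to a large group and meta to a fluoro group, so the core alone cannot be named as the source of the gap. Going by these compounds, the true size of the new step also remains unknown. Open, on these data alone, is how a methoxy group or an amine at the same place would read in this assay on either core.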